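The compounds below may be only part of what the source reports. "The series", "measured", "known", "first", "only" and "open" are said of these compounds alone.

Measured in a functional assay on HeLa cells (Homo sapiens) for inhibition, read by MTT assay, with a stated time of 48 h; a lower number here means a stronger inhibitor, a higher number a weaker inhibitor:
- compound 1 `COc1ccc2c(=O)c(/C=C/C(=O)Nc3cccc(Cl)c3)coc2c1`: 11900 nM
- compound 2 `COc1ccc(CNC(=O)/C=C/c2coc3cc(O)ccc3c2=O)cc1`: > 100000 nM (a limit, not a number)
- compound 3 `COc1ccc2c(=O)c(/C=C/C(=O)NCc3ccccc3)coc2c1`: 33400 nM

Of the two numeric values in this assay, the higher belongs to compound 3 at 33400 nM. The nearest numeric neighbour is compound 1 at 11900 nM.

The next compound to be measured is compound 4 `COc1ccc(NC(=O)/C=C/c2coc3cc(OC)ccc3c2=O)cc1`, with 4-methoxyphenyl in place of benzyl on an amide-type nitrogen. For the measured compounds named here, only one measured step bears on this nitrogen: a 2.8-fold higher number from compound 1 to compound 3 (0.45 log units; beyond the scatter), with benzyl in place of 3-chlorophenyl. Read in reverse, that modest step suggests a lower number once benzyl leaves, although 4-methoxyphenyl is not 3-chlorophenyl and no measured step covers it. A modest drop in this assay is therefore expected, no larger than the measured step and possibly within the scatter. The expected change is a 1.9-fold lower number from compound 3 to compound 4 (0.27 log units; within the scatter).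

For compound 4 the estimated value is 18000 nM, with an expected range of 6000 nM to 55000 nM.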

Compound 4, half-maximal inhibitory concentration: 13000 nM
Estimate against measurement, compound 4: 1.4-fold (0.14 log units) above; low and high end bracket the measured number.
By their numbers in this assay, from the lowest: compounds 1 and 4 (each within the scatter of the next); then compound 3. At a limit, above all of these: compound 2.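

Replacing benzyl with 4-methoxyphenyl on the amide-type nitrogen gives a 2.6-fold lower number from compound 3 to compound 4 (0.41 log units; beyond the scatter) in this assay, so benzyl now gives the higher number against two substituted phenyl groups, 3-chlorophenyl and 4-methoxyphenyl, rather than one. The two substituted phenyl groups do not separate, with a 1.1-fold higher number from compound 1 to compound 4 (0.04 log units; within the scatter), so compound 1 and compound 4 cannot be ordered in this assay. No measured property of these groups bears on this result.

Going by these compounds, it remains open whether an unsubstituted phenyl, or a phenyl carrying an amine or a carboxylic acid, would sit with compound 1 and compound 4 or with compound 3. A longer chain between the amide-type nitrogen and the phenyl ring is also untested in the compounds shown, so the benzyl comparison cannot yet be extended to chain length.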